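This account rests on a few compounds, and the source may have more. Where it says the series, first, only, none or still open, it means among the compounds named here.

Compounds measured so far:
compound 1, `COc1ccc(F)c([C@H]2CC[C@H](COc3cccc([C@H](C4CC4)[C@H](C)C(=O)O)c3)CC2)c1` — 0.2 nM
compound 2, `COc1ccc(F)c([C@H]2CC[C@H](COc3cccc([C@H](C4CC4)[C@H](F)C(=O)O)c3)CC2)c1` — 54 nM
compound 3, `COc1ccc(F)c([C@H]2CC[C@H](COc3cccc([C@H](C4CC4)[C@@H](F)C(=O)O)c3)CC2)c1` — 1.1 nM

These three compounds share a common core and differ only at the acid-bearing carbon. In a functional assay on HEK293 cells for agonist activity at Free fatty acid receptor 1 (Homo sapiens), read by FLIPR and calcium flux (a lower number here means that less compound is needed, a higher number that more compound is needed for the effect), compound 3 stands second highest of the three numbers. Its nearest neighbour is compound 1, with a 5.5-fold higher number from compound 1 to compound 3 (0.74 log units; beyond the scatter). Its furthest is compound 2, with a 49-fold lower number from compound 2 to compound 3 (1.69 log units; beyond the scatter), a step that rests on (the fact that compounds 2 and 3 differ only in the configuration as drawn).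

Compound 4, `COc1ccc(F)c([C@H]2CC[C@H](COc3cccc([C@H](C4CC4)[C@](C)(F)C(=O)O)c3)CC2)c1`, has not yet been measured. It differs from compound 3 by methyl in place of hydrogen on a saturated chain carbon bound to a carbonyl carbon, a fluorine atom and a saturated chain carbon. The acid-bearing carbon of compound 4 thus carries both the methyl of compound 1 and the fluorine of compound 3.

Within the data shown here, two measured steps bear on this. Swapping methyl for fluorine gave a 270-fold higher number from compound 1 to compound 2 (2.43 log units; beyond the scatter) in one configuration and a 5.5-fold higher number from compound 1 to compound 3 (0.74 log units; beyond the scatter) in the other, so the methyl has been the better substituent in both cases. Adding a methyl back to compound 3 is therefore not expected to raise the number, and it may lower it slightly; the expected size of the step from compound 3 to compound 4 in this assay is a 1.1-fold lower number from compound 3 to compound 4 (0.04 log units; within the scatter), not beyond the scatter. The estimate for compound 4 in this assay is 1 nM, with a range from 0.2 nM to 6 nM.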

Compound 4, half-maximal effective concentration: 6.1 nM
Estimate against measurement, compound 4: 6.1-fold (0.79 log units) below, and the stated range ends below it.
By their numbers in this assay, from the lowest: compound 1; then compound 3; then compound 4; then compound 2.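

On this acid-bearing carbon, the methyl that goes with the lowest number in the set does not help once fluorine is present: adding it gives a 5.5-fold higher number from compound 3 to compound 4 (0.74 log units; beyond the scatter) in this assay. Fluorine in place of hydrogen on the methyl-bearing carbon also costs a great deal, with a 31-fold higher number from compound 1 to compound 4 (1.48 log units; beyond the scatter), so carrying both groups does not combine the merits of compound 1 and compound 3, and compound 1, with methyl and hydrogen on this carbon, keeps the lowest number of the four. Carrying both groups is still better than the less favourable single-fluorine configuration, as an 8.9-fold lower number from compound 2 to compound 4 (0.95 log units; beyond the scatter) shows, so the outcome at this carbon depends on the arrangement of its groups as well as on which groups are there.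

The compounds shown leave open how an ethyl, a hydroxyl or a second fluorine on this carbon would behave, and how the opposite configuration of compound 4 at this carbon would compare. What they offer gives no measured cause for the rise from compound 3 to compound 4.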